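Amine variation on the shared core: compound 3 to compound 4

The source may hold more compounds than are shown below. What is called first, only, known or untested is meant among the compounds shown, and "the series" means these compounds.

Of the compounds shown here, three have been tested in an assay on nucleic acid for inhibition of Nucleic Acid, read by fluorescence, tested at 100 uM; a higher number here means more inhibition at the concentration tested (going by the name of the read-out), a lower number less inhibition. Compound 1 `CCCCC(O)Cn1cc(CN(C)CC2CCCCC2)nn1` gives 47% in this assay. Compound 2 `O=C(COc1ccccc1)OC1CCCCC1n1cc(CN2CCC(c3ccccc3)CC2)nn1` gives 42%. Compound 3 `CN(CCCc1ccccc1)Cc1cn(C2CCCCC2OC(=O)COc2ccccc2)nn1` gives 42%, level with compound 2 at the digits shown and within the scatter of compound 1, so no ordering among the three can be read. Compound 4 `CCCCN(CCCC)Cc1cn(C2CCCCC2OC(=O)COc2ccccc2)nn1` has not been measured. It differs from compound 3 in one place: dibutylamino in place of methyl(3-phenylpropyl)amino on a saturated chain carbon bound to an aromatic carbon. For the measured compounds named here, no step between measured compounds isolates this change, so its size is unknown; a shift of no more than the usual scatter, in either direction, is expected. Compound 4 is estimated to give 42% with a range of 30% to 54%. This estimate means an expected step of no change at the digits printed from compound 3 to compound 4 (within the scatter), within the scatter.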

Compound 4, a percentage reported as inhibition, at one concentration (the size of the read-out at that concentration, not a potency): 26%
Compound 4: middle estimate off by 16 percentage points, on the high side, and the stated range ends above it.
By their numbers in this assay, from the lowest: compound 4; then compounds 2, 3 and 1 (each within the scatter of the next).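

The amine at this saturated chain carbon bound to an aromatic carbon matters in this assay, where dibutylamino in place of methyl(3-phenylpropyl)amino gives a number 16 percentage points lower from compound 3 to compound 4 (beyond the scatter). The entering group has no ring, while the leaving group carries a six-membered aromatic ring, and the hydrogen-bond donor and acceptor counts are the same. No evidence on hand accounts for the step, which rests on this single pair.

As far as these compounds go, whether the aromatic ring or the chain pattern on the nitrogen decides the number stays open. A butyl(methyl)amino group on the same carbon would help separate the two.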